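This account rests on a few compounds, and the source may have more. Where it says the series, first, only, none or still open, it means among the compounds named here.

Compound 1 `CNCCCNc1c(C(=O)NCc2ccc(F)cc2)nc(Br)c2cccnc12`: > 10000 nM
Compound 2 `Cc1ccc(S(=O)(=O)Oc2c(C(=O)NCc3ccc(F)cc3)nc(Br)c3cccnc23)cc1`: "not determined" (no result reported)

In a functional assay on MCF7 cells (Homo sapiens) for cytotoxicity, read by MTT assay, with a stated time of 72 h (on this read-out higher numbers stand for weaker inhibition and lower numbers for stronger inhibition), compound 1 gives > 10000 nM, which is a limit of the assay. Compound 2 stands without a single number, at "not determined" (no result reported). Next is compound 3 `COC(=O)CNc1c(C(=O)NCc2ccc(F)cc2)nc(Br)c2cccnc12`. The change ((methoxycarbonyl)methyl)amino in place of ((4-methylphenyl)sulfonyl)oxy on an aromatic carbon puts ((methoxycarbonyl)methyl)amino in place of ((4-methylphenyl)sulfonyl)oxy on an aromatic carbon, para to a bromo group. With no number for compound 2, no size or direction can be expected for this step in this assay. Weak inhibition is expected instead, by analogy with compound 1 at > 10000 nM. Compound 3 is estimated at 12000 nM, with an expected range of 4000 nM to 30000 nM.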

Compound 3, half-maximal inhibitory concentration: > 10000 nM
Compound 3: only a limit was reported; the forecaster's own chance of this, stated with the estimate: 70%; the middle value is on the limit's open side.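

Compound 1 and compound 3 are both reported only as limits, and compound 2 has no number, so no step can be read among them. The compounds shown leave open which change on the shared core, if any, would give a readable value in this assay.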